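The compounds below may be only part of what the source reports. "The series", "measured", "known", "first", "only" and "open" are said of these compounds alone.

Measured so far:
- Compound 1, `CC(C)=CCc1cc(C(=O)Nc2cc3ccc(OCC4CCCN(C)C4)c(C)c3oc2=O)ccc1O`: 2640 nM
- Compound 2, `CC(C)=CCc1cc(C(=O)Nc2cc3ccc(OCCCNCC(C)C)c(C)c3oc2=O)ccc1O`: 1320 nM
- Compound 3, `CC(C)=CCc1cc(C(=O)Nc2cc3ccc(OCCCN(C(C)C)C(C)C)c(C)c3oc2=O)ccc1O`: 1310 nM

All three share one core and differ only in the amine carried on the chain attached to the aromatic oxygen. In a functional assay on MCF7 cells (Homo sapiens) for antiproliferative activity (a lower number here means a stronger inhibitor, a higher number a weaker inhibitor), compound 3 gives 1310 nM, and the three numbers lie close together: a 2.0-fold lower number from compound 1 to compound 3 (0.30 log units; within the scatter) and a 1.0-fold lower number from compound 2 to compound 3 (0.00 log units; within the scatter), so none of the three can be told apart beyond the scatter.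

Compound 4, `CC(C)=CCc1cc(C(=O)Nc2cc3ccc(OCCCN[C@H](C)c4ccccc4)c(C)c3oc2=O)ccc1O`, has not yet been measured in this assay. It differs from compound 3 in one place: (1-phenylethyl)amino in place of diisopropylamino on a saturated chain carbon, three bonds along the chain from an oxygen on an aromatic ring

Among the compounds with values here, the steps that bear on this are the two amine swaps already seen, a 2.0-fold lower number from compound 1 to compound 2 (0.30 log units; within the scatter) and a 1.0-fold lower number from compound 2 to compound 3 (0.00 log units; within the scatter), neither of which moved the number beyond the scatter. Within the data shown here, the phenyl ring that enters here has no counterpart among the measured compounds, so its effect is unknown. On the evidence of the other amine changes, the expected step is a 1.0-fold lower number from compound 3 to compound 4 (0.00 log units; within the scatter), with no change beyond the scatter. Compound 4 is therefore estimated at 1300 nM, within a range of 500 nM to 3500 nM.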

Compound 4, half-maximal inhibitory concentration: 1450 nM
For compound 4 the middle estimate is 1.1-fold (0.05 log units) below the measured one, within the range that was stated.
By their numbers in this assay, from the lowest: compounds 3, 2, 4 and 1 (each within the scatter of the next).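

In this assay, the position three bonds along the chain from the oxygen on the aromatic ring now carries a six-membered aromatic ring of carbon only, yet a 1.1-fold higher number from compound 3 to compound 4 (0.04 log units; within the scatter) with (1-phenylethyl)amino in place of diisopropylamino, and a 1.1-fold higher number from compound 2 to compound 4 (0.04 log units; within the scatter) with 1-phenylethyl in place of isobutyl on the amine nitrogen. Even against the ring-bearing 1-methylpiperidin-3-yl side chain, the comparison gives a 1.8-fold lower number from compound 1 to compound 4 (0.26 log units; within the scatter), so all four compounds remain indistinguishable, and this larger change at this position brings no measurable shift. No supporting data are available to explain this result.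

On these data alone, whether any group at this position can move the number beyond the scatter remains unknown. A carboxylic acid in place of the amine, a plain benzylamine, or the opposite stereoisomer of the 1-phenylethyl group would each test this further.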